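Shifting the Chlorine on the Sulfonyl Aryl Ring

A few compounds are considered here, and "the series" means these few. Any claim that something is new, unique, unknown or untested is made for them only; others in the source may bear on it.

Compound 1 `N=C(NS(=O)(=O)c1ccc(Cl)cc1)N1CCN(c2cc3c(cc2F)c(=O)c(C(=O)O)cn3C2CC2)CC1` is tested in a functional assay on HeLa cells (Homo sapiens) for antiproliferative activity, read by MTT assay, with a stated time of 72 h (a lower number here means a stronger inhibitor, a higher number a weaker inhibitor), where compound 1 gives 32 nM. Compound 2 `CCn1cc(C(=O)O)c(=O)c2cc(F)c(N3CCN(C(=N)NS(=O)(=O)c4ccccc4Cl)CC3)cc21` gives 32 nM and compound 3 `CCn1cc(C(=O)O)c(=O)c2cc(F)c(N3CCN(C(=N)NS(=O)(=O)c4ccc(Cl)cc4)CC3)cc21` gives 32 nM, so compound 1 stands level with both. The move from compound 1 to compound 4 `N=C(NS(=O)(=O)c1cccc(Cl)c1)N1CCN(c2cc3c(cc2F)c(=O)c(C(=O)O)cn3C2CC2)CC1` is 3-chlorophenyl in place of 4-chlorophenyl on a sulfonyl sulfur. Among the measured compounds shown here, two measured steps bear on it. The shift no change at the digits printed from compound 2 to compound 3 (within the scatter) shows that exchanging one chlorophenyl for another on the sulfonyl sulfur left this assay unchanged, and no change at the digits printed from compound 1 to compound 3 (within the scatter) shows the same indifference to the group on the aromatic nitrogen. Compound 4, carrying a third chlorophenyl, is therefore expected to stay within the scatter, a step of no change at the digits printed from compound 1 to compound 4 (within the scatter). Compound 4 is estimated at 32 nM, between 15 nM and 70 nM.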

Compound 4, half-maximal inhibitory concentration: 32 nM
Compound 4: middle estimate and measured number agree at the digits printed, and the stated range covers the measured number.
By their numbers in this assay, from the lowest: compounds 1, 2, 3 and 4 (each within the scatter of the next).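

What compounds 2 and 3 showed extends to a new chlorine placement and to the compound with cyclopropyl on the aromatic nitrogen: the step reads no change at the digits printed from compound 1 to compound 4 (within the scatter). In this assay, 3-chlorophenyl and 4-chlorophenyl on the sulfonyl sulfur therefore cannot be told apart in this series, as 2-chlorophenyl and 4-chlorophenyl could not in the ethyl series. No measurement offered here accounts for this flat result.

The compounds shown leave open whether the chlorine matters at all, since each carries one on the ring. An unsubstituted phenyl, a methoxy or nitrile group in its place, or a plain alkyl chain on the sulfonyl sulfur would test this.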